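Series notes: benzylamine change from compound 2 to compound 4

A few compounds are considered here, and "the series" means these few. Any claim that something is new, unique, unknown or untested is made for them only; others in the source may bear on it.

In an ADME assay for permeability, using PAMPA, with a stated time of 30 min, at pH 7.4 (on this read-out lower numbers stand for lower permeability and higher numbers for higher permeability), compound 2 `COc1cccc(CNCCCNc2ccnc3cc(-c4cc(C(F)(F)F)cc(C(F)(F)F)c4)ccc23)c1O` gives 237 10^-6 cm/s, the second highest of the three numbers. Compound 1 `Fc1ccc(Oc2ccc3c(NCCCNCc4ccco4)ccnc3c2)cc1` gives 317 10^-6 cm/s, within the scatter of compound 2; compound 3 `c1coc(CNCCCNc2ccnc3cc(C4CCCCC4)ccc23)c1` gives 23 10^-6 cm/s. Among the measured compounds shown here, the only step between measured compounds, a 14-fold lower number from compound 1 to compound 3 (1.14 log units; beyond the scatter), sits on the core and not on the chain, so it does not bear on the present change. Compound 4 `COc1ccc(F)cc1CNCCCNc1ccnc2cc(-c3cc(C(F)(F)F)cc(C(F)(F)F)c3)ccc12` differs from compound 2 by 5-fluoro-2-methoxyphenyl in place of 2-hydroxy-3-methoxyphenyl on a saturated chain carbon bound to an amine nitrogen. For the measured compounds named here, no measured step tests this part of the molecule, so no step beyond the scatter is expected in this assay, and the step of a 1.1-fold higher number from compound 2 to compound 4 (0.04 log units; within the scatter) is estimated to stay within it. Compound 4 is therefore expected to give about 260 10^-6 cm/s, in a range from 140 10^-6 cm/s to 480 10^-6 cm/s.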

Compound 4, apparent permeability in the ADME assay: 237 10^-6 cm/s
Compound 4: the middle estimate sits 1.1-fold (0.04 log units) above what was measured; low and high end bracket the measured number.
By their numbers in the ADME assay, from the lowest: compound 3; then compounds 2, 4 and 1 (each within the scatter of the next).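

Among the compounds shown here, in the ADME assay the first measured step at this position, no change at the digits printed from compound 2 to compound 4 (within the scatter), shows that 5-fluoro-2-methoxyphenyl, with 0 hydrogen-bond donors, can stand in place of 2-hydroxy-3-methoxyphenyl, with 1, without a step beyond the scatter. In a physicochemical assay for solubility, with a stated time of 18 h, at pH 7.4 (a higher number here means a more soluble compound, a lower number a less soluble compound), compound 2 gives 32000 nM and compound 4 gives 32000 nM as well, so neither read-out separates the two groups. Nothing at hand accounts for this level result.

From the compounds shown here alone, whether an amine or a carboxylic acid on a saturated chain carbon bound to an amine nitrogen would move either read-out stays open.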